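Pyridin-4-yl in place of 2-fluorophenyl: working notes

The compounds below may be only part of what the source reports. "The series", "measured", "known", "first", "only" and "open" are said of these compounds alone.

Going by the values given here, in a functional assay on B16-F10 cells (Mus musculus) for antiproliferative activity, read by MTT assay, with a stated time of 48 h (a higher number here means a weaker inhibitor, a lower number a stronger inhibitor), compound 1 (`CC(=O)N1N=C(c2ccc3ccccc3c2)OC1c1ccccc1F`) gives 6.05 ug/mL, the upper end of the numbers so far. Among the compounds with values here, compound 3 (`CC(=O)N1N=C(c2ccc3ccccc3c2)OC1c1cccnc1`) gives 3.06 ug/mL, and compound 2 (`CC(=O)N1N=C(c2ccc3ccccc3c2)OC1c1ccc2ccccc2c1`) gives 1.56 ug/mL, the only value beyond the scatter of compound 1. Compound 4 (`CC(=O)N1N=C(c2ccc3ccccc3c2)OC1c1ccncc1`) carries pyridin-4-yl in place of 2-fluorophenyl on a saturated ring carbon. Within the data shown here, the one measured step that bears on this is the pyridin-3-yl change, a 2.0-fold lower number from compound 1 to compound 3 (0.30 log units; within the scatter). Among the measured compounds shown here, no measurement yet covers pyridin-4-yl itself, so a step of similar size towards a lower number, not clearly beyond the scatter, is expected. The estimated step is a 1.9-fold lower number from compound 1 to compound 4 (0.28 log units; within the scatter). Compound 4 is expected at 3.2 ug/mL, with an estimated range of 1.5 ug/mL to 6.5 ug/mL.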

Compound 4, half-maximal inhibitory concentration: 2.97 ug/mL
Compound 4: middle estimate off by 1.1-fold (0.03 log units), on the high side; the range from low to high includes it.
By their numbers in this assay, from the lowest: compounds 2, 4, 3 and 1 (each within the scatter of the next, the first and the last beyond it).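

In this assay the pyridin-4-yl change gives a 2.0-fold lower number from compound 1 to compound 4 (0.31 log units; beyond the scatter), so a pyridine ring in place of 2-fluorophenyl on this saturated ring carbon now gives a modest step just beyond the scatter. Pyridin-4-yl in place of pyridin-3-yl gives a 1.0-fold lower number from compound 3 to compound 4 (0.01 log units; within the scatter), so this assay does not separate these two pyridine groups. No measured evidence bears on the origin of either step. On these data alone, how a carboxylic acid or an amine on this carbon would read remains open, as does whether these steps hold on other cells.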